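The source may report more compounds than this note shows. Statements on the series, on what has been measured and on what is new or still open speak of the compounds shown alone.

Measured compounds in a functional assay on A549 cells (Homo sapiens) for cytotoxicity, read by MTT assay, with a stated time of 48 h; on this read-out lower numbers stand for stronger inhibition and higher numbers for weaker inhibition: compound 1 `COCOCc1cc(OC)ccc1-c1cc2ccccc2c(=O)[nH]1` gives 45300 nM; compound 2 `C=CCn1c(-c2cc(OC)c(OC)cc2C=C)cc2ccccc2c1=O` gives 43200 nM; compound 3 `C=CCn1c(-c2ccc(OC)cc2C=C)cc2ccccc2c1=O` gives 17200 nM.

Compound 1 stands highest of the three, though its number and that of compound 2 lie within the scatter of each other, while compound 3 sits well apart. One step is counted here: a 2.5-fold higher number from compound 3 to compound 2 (0.40 log units; beyond the scatter), the change being (methoxy in place of hydrogen on an aromatic carbon). The difference between the cores of compound 1 and compound 3 is not broken down here.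

Compound 4 `COCOCc1cc(OC)c(OC)cc1-c1cc2ccccc2c(=O)[nH]1` has not been measured. It differs from compound 1 by methoxy in place of hydrogen on an aromatic carbon. This is the same kind of change as that from compound 3 to compound 2, though the surroundings are not identical: in compound 4 the new group stands para to a (methoxymethoxy)methyl group, whereas in compound 2 it stands para to a vinyl group. Because the earlier step of a 2.5-fold higher number from compound 3 to compound 2 (0.40 log units; beyond the scatter) raised the number, a step of similar size is expected, a 2.0-fold higher number from compound 1 to compound 4 (0.30 log units; within the scatter). Compound 4 is therefore estimated at 90000 nM, between 40000 nM and 200000 nM.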

Compound 4, half-maximal inhibitory concentration: 85100 nM
For compound 4 the middle estimate is 1.1-fold (0.02 log units) above the measured one, and the stated range covers the measured number.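

In this assay, methoxy in place of hydrogen on the aromatic carbon para to a (methoxymethoxy)methyl group gives a 1.9-fold higher number from compound 1 to compound 4 (0.27 log units; within the scatter), so this step on its own does not clear the scatter. Set beside the earlier step, the change reads alike on the two cores, with both numbers going the same way and the two sizes not separable: the same change on two cores in this assay, a 2.5-fold higher number (0.40 log units; beyond the scatter) from compound 3 to compound 2 and a 1.9-fold higher number (0.27 log units; within the scatter) from compound 1 to compound 4, 1.3-fold (0.13 log units) apart, within the scatter of two such steps. Among these compounds, this agreement rests on only two pairs, one of them within the scatter, so it supports carrying the change between these two cores but gives no rule for any other core, and it says nothing about why the numbers move.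

The compounds shown leave open whether another group on that same aromatic carbon, such as ethoxy, fluorine, hydroxyl or an amine, would read as methoxy does. They also leave open what replacing the (methoxymethoxy)methyl group with a plain hydroxymethyl or a carboxylic acid would do in this assay.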